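From hydroxycarbamoyl to 2-(hydroxycarbamoyl)ethyl: compound 2 to compound 3

This account rests on a few compounds, and the source may have more. Where it says the series, first, only, none or still open, it means among the compounds named here.

In a functional assay on HCT-116 cells (Homo sapiens) for cytotoxicity, read by MTT assay, with a stated time of 72 h (a higher number here means a weaker inhibitor, a lower number a stronger inhibitor), compound 2 `O=C(Nc1ccc(C(=O)NO)cc1)Nc1ccc([N+](=O)[O-])cc1` gives 28400 nM, level with compound 1 `COc1ccc(NC(=O)Nc2ccc(C(=O)NO)cc2)cc1` at 22300 nM. The two form the whole measured set so far. Compound 3 `O=C(CCc1ccc(NC(=O)Nc2ccc([N+](=O)[O-])cc2)cc1)NO` keeps the nitro group of compound 2 and has 2-(hydroxycarbamoyl)ethyl in place of hydroxycarbamoyl on an aromatic carbon. Among the compounds with values here, the only measured step, a 1.3-fold higher number from compound 1 to compound 2 (0.11 log units; within the scatter), is nitro in place of methoxy, which lies at a different place and stays within the scatter. Within the data shown here, it therefore says little about this change, and no measured compound carries the 2-(hydroxycarbamoyl)ethyl group. The expectation rests on the structural change alone and is uncertain: a moderate move towards a lower number in this assay, with no change not excluded. The expected step is a 3.2-fold lower number from compound 2 to compound 3 (0.50 log units; beyond the scatter). For compound 3 the estimated value is 9000 nM, with an expected range of 1500 nM to 35000 nM.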

Compound 3, half-maximal inhibitory concentration: 6370 nM
Estimate against measurement, compound 3: 1.4-fold (0.15 log units) above; measured number inside the range.
By their numbers in this assay, from the lowest: compound 3; then compounds 1 and 2 (each within the scatter of the next).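

In this assay, within the data shown here, 2-(hydroxycarbamoyl)ethyl in place of hydroxycarbamoyl on an aromatic carbon gives a 4.5-fold lower number from compound 2 to compound 3 (0.65 log units; beyond the scatter) and is the first step beyond the scatter. This position therefore responds to change, whereas nitro in place of methoxy at the other place gave a 1.3-fold higher number from compound 1 to compound 2 (0.11 log units; within the scatter) and stayed within the scatter. The step is modest, and no measurement at hand bears on what lies behind it.

Still open, from the compounds shown here alone, is whether a longer chain carrying the hydroxycarbamoyl group moves the number further, or whether a carboxylic acid in place of the hydroxycarbamoyl group at the end of the chain keeps the step. Also open, going by these compounds, is whether 2-(hydroxycarbamoyl)ethyl gives a step of similar size when methoxy stands in place of nitro.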